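2,6-Dichlorophenyl to 3,5-difluorophenyl on a shared core

A few compounds are considered here, and "the series" means these few. Any claim that something is new, unique, unknown or untested is made for them only; others in the source may bear on it.

In a functional assay on MCF7 cells (Homo sapiens) for inhibition, read by MTT assay, with a stated time of 48 h, tested at 10 uM (a higher number here means more inhibition of growth at the concentration tested, a lower number less inhibition of growth), compound 3 `Cc1oc2c([C@H]3CCN(C)C[C@H]3O)c(O)cc(O)c2c(=O)c1C(O)c1c(Cl)cccc1Cl` gives 33% as its result. That lies within the scatter of compound 1 `Cc1cc(=O)c2c(O)cc(OCc3ccc([N+](=O)[O-])cc3)c([C@H]3CCN(C)C[C@H]3O)c2o1` at 39% and well clear of compound 2 `Cc1oc2c([C@H]3CCN(C)C[C@H]3O)c(O)cc(O)c2c(=O)c1C(O)c1ccc(Cl)cc1` at 6% in the same kind of measurement. The still unmeasured compound 4 `Cc1oc2c([C@H]3CCN(C)C[C@H]3O)c(O)cc(O)c2c(=O)c1C(O)c1cc(F)cc(F)c1` carries 3,5-difluorophenyl in place of 2,6-dichlorophenyl on a saturated chain carbon bound to an aromatic carbon and an oxygen on a saturated carbon. The counted difference is 3,5-difluorophenyl in place of 2,6-dichlorophenyl on a saturated chain carbon bound to an aromatic carbon and an oxygen on a saturated carbon and the rest of the structure stays the same. Among the measured compounds shown here, only one measured step changes this same place, and compound 4 gives up the 2,6-dichlorophenyl group that came in with a number 27 percentage points higher from compound 2 to compound 3 (beyond the scatter) so a partial return towards compound 2 is expected. For the measured compounds named here, compound 1 offers no step at this place, and no measured compound yet carries a 3,5-difluorophenyl group, so the expectation remains loose. The estimated move in this assay is a number 15 percentage points lower from compound 3 to compound 4 (beyond the scatter) and it rests on that single step. In this assay compound 4 is estimated at 18% with an expected range from 4% to 38% for the coming measurement.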

Compound 4, percent growth inhibition at one concentration: 25%
Beside the measured number, compound 4's estimate is 7 percentage points below it, within the range that was stated.
By their numbers in this assay, from the lowest: compound 2; then compounds 4, 3 and 1 (each within the scatter of the next, the first and the last beyond it).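

In this assay, 3,5-difluorophenyl in place of 2,6-dichlorophenyl on the saturated chain carbon gives a number 8 percentage points lower from compound 3 to compound 4 (within the scatter), so the two groups cannot be told apart at this position. Among the compounds shown here, measured against 4-chlorophenyl, the same group gives a number 19 percentage points higher from compound 2 to compound 4 (beyond the scatter), which means that compound 3 is no longer the only compound to stand clear of compound 2. Among these three compounds, the two phenyl groups carrying two halogen atoms both lie beyond the scatter of the group carrying one, and none of the three goes against this, but the kind, number and placing of the halogens all change together; nothing available here explains the difference between these groups.

Which of those three features matters remains open, and a plain phenyl group on the same chain carbon would give a first reference point without any halogen. From the compounds shown here alone, it is also open how an amine or a carboxylic acid in place of the phenyl ring would read at this position, and whether the hydroxy group on that carbon contributes at all.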